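A few compounds are considered here, and "the series" means these few. Any claim that something is new, unique, unknown or untested is made for them only; others in the source may bear on it.

Compound 1 `O=C(CCCCC(S)CCS)NO`: 49.3%
Compound 2 `O=C(CCCCC1CCSS1)Nc1ccc(OC(F)(F)F)cc1`: 84.5%

In a functional assay on HO8910 cells (Homo sapiens) for inhibition, read by MTT assay, with a stated time of 24 h, tested at 100 ug/mL (a lower number here means less inhibition of growth, a higher number more inhibition of growth at the concentration tested), compound 1 gives 49.3%, the lower of the two numbers. Compound 2 gives 84.5%, and the gap between them lies beyond the scatter. Within the data shown here, these two compounds differ in more than one place, so no single-place step is available to calibrate the next change.

Compound 3 `O=C(CCCCC(S)CCS)Nc1ccccc1` is the next to be tested. It keeps the core of compound 1, with one change: phenyl in place of hydroxy on an amide-type nitrogen, which is phenyl in place of hydroxy on an amide-type nitrogen. A moderate upward step in this assay is expected, possibly beyond the scatter. Among the measured compounds shown here, the only support is that compound 2, which also has an aromatic ring on an amide-type nitrogen, gives 84.5%. The estimated change is a number 15.7 percentage points higher from compound 1 to compound 3 (beyond the scatter). For compound 3, the expected value is 65%, with an estimated range of 45% to 83%.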

Compound 3, percent growth inhibition at one concentration: 13.7%
Estimate against measurement, compound 3: 51.3 percentage points above; measured number outside the range, below it.
By their numbers in this assay, from the lowest: compound 3; then compound 1; then compound 2.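

In this assay, the series now has its first single-place step: phenyl in place of hydroxy on an amide-type nitrogen gives a number 35.6 percentage points lower from compound 1 to compound 3 (beyond the scatter). On the core of compound 1, the group on this nitrogen therefore has a large effect on the read-out, and hydroxy retains more growth inhibition than phenyl. Nothing available bears on the reason for this loss.

A single step cannot show whether the loss follows from removing hydroxy, adding phenyl, or both, nor whether the same change would have the same effect on the core of compound 2. On these data alone, it also remains open how an amine, a methyl group or a benzyl group on this nitrogen would compare with hydroxy and phenyl.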